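This account rests on a few compounds, and the source may have more. Where it says the series, first, only, none or still open, it means among the compounds named here.

Working notes on the sulfonamide series against an assay on isolated protein for inhibition of alkaline phosphatase, tissue-nonspecific isozyme (Homo sapiens); a higher number here means a weaker inhibitor, a lower number a stronger inhibitor.

Of the compounds shown here, three have numbers so far. Compound 1 `COc1ccc(Cl)cc1S(=O)(=O)Nc1cncc(C(=O)Nc2ccccc2)c1` gives 310 nM in this assay, the highest of the three. Compound 2 `COc1ccc(C(F)(F)F)cc1S(=O)(=O)Nc1cnc2ccccc2c1` gives 26 nM, and compound 3 `COc1ccc(Br)cc1S(=O)(=O)Nc1cccnc1` gives 43 nM. Compound 1 thus stands apart from the other two, both of which are beyond the scatter from it; compound 2 is the furthest and compound 3 the nearest. These three differ from one another in more than one place, so the numbers are not taken apart into single steps.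

Compound 4 `COc1ccc(Cl)cc1S(=O)(=O)Nc1cncc(-c2ccc(Cl)cc2)c1` is not yet measured. It shares the core of compound 1 and differs in one place: 4-chlorophenyl in place of phenylcarbamoyl on an aromatic carbon

Among the measured compounds shown here, no measured pair isolates this exchange. The two other compounds carry no phenylcarbamoyl and both sit well below compound 1, which leaves room for a lower number when that group is taken out, though what enters in its place has not been tried in this series. A step toward a lower number, of modest size and close to the edge of the scatter, is expected for a 2.1-fold lower number from compound 1 to compound 4 (0.32 log units; beyond the scatter).

For compound 4 the estimate in this assay is 150 nM, with a range from 50 nM to 450 nM.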

Compound 4, half-maximal inhibitory concentration: 198 nM
The estimate for compound 4 lay 1.3-fold (0.12 log units) below the measured number; measured number inside the range.
By their numbers in this assay, from the lowest: compounds 2 and 3 (each within the scatter of the next); then compounds 4 and 1 (each within the scatter of the next).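

In this assay, among the compounds shown here, the first single exchange gives a 1.6-fold lower number from compound 1 to compound 4 (0.19 log units; within the scatter), with 4-chlorophenyl in place of phenylcarbamoyl on an aromatic carbon, two atoms from the ring nitrogen, so this pair does not separate the two groups. For the compounds shown here, the hydrogen-bond donor and hydrogen-bond acceptor counted on phenylcarbamoyl are absent from 4-chlorophenyl, and in this one pair their absence leaves the two numbers within the scatter of each other, which the earlier compounds, differing in more than one place, could not show. No measurement in hand bears on why these two groups read alike at this position.

On these data alone, it remains open whether the chlorine of 4-chlorophenyl counts for anything here, which a plain phenyl on the same carbon would test, and whether the amide link of phenylcarbamoyl can be replaced by a single ether oxygen or a methylene between the two rings. Also open, as far as these compounds go, is how far this position accepts groups of another kind, such as a carboxylic acid, an aminomethyl group or a morpholine, since the two groups compared here both carry a carbon-only aromatic ring.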